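The source may hold more compounds than are shown below. What is called first, only, known or untested is meant among the compounds shown, and "the series" means these compounds.

Two compounds of this set have so far been examined in a functional assay on MCF7 cells (Homo sapiens) for cytotoxicity, read by MTT assay, with a stated time of 24 h; a higher number here means a weaker inhibitor, a lower number a stronger inhibitor. Compound 1, `CCOC(=O)c1csc(-c2nc3ccccc3n2C)n1`, returns only a limit in this assay, > 20000 nM, and so no number. Compound 2, `Cc1nc(-c2nc3ccccc3n2Cc2ccccc2)sc1C(=O)O`, likewise returns only a limit in this assay, > 20000 nM. On the numbers shown, compound 2 therefore stands nowhere in particular: both recorded values sit at the limit of > 20000 nM in this assay, at which 2 of the 2 values shown sit, and no order between compound 1 and compound 2 can be drawn from them.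

Compound 3, `Cc1nc(-c2nc3ccccc3n2Cc2ccccc2)sc1C(=O)N1CCCCC1`, is the next compound to be measured. It differs from compound 2 in one place: piperidin-1-yl in place of hydroxy on a carbonyl carbon, on a carbonyl carbon whose other neighbour is an aromatic carbon; cut one bond further out, carboxy becomes (piperidin-1-yl)carbonyl. The two measured values, both limits, say nothing about how a change of this kind moves the half-maximal inhibitory concentration. The expected step is accordingly a number no higher from compound 2 to compound 3 (the limit leaves the size open), nothing beyond the usual scatter in either direction. For compound 3 the half-maximal inhibitory concentration in this assay is expected near 20000 nM, within a range from 5000 nM to 60000 nM, and quite possibly again only as a limit.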

Compound 3, half-maximal inhibitory concentration: > 20000 nM
Compound 3 gave a limit, no number; the forecaster's own chance of this, stated with the estimate: 70%; the middle value sits exactly at the limit.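

Compound 2 and compound 3 both return only a limit in this assay, so no step can be read between them and the effect of piperidin-1-yl in place of hydroxy stays unsized: the limit of > 20000 nM in this assay, at which 3 of the 3 values shown sit. The compounds shown leave open whether any change to the shared core gives a measurable half-maximal inhibitory concentration in this assay.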